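The source may report more compounds than this note shows. Statements on the series, on what has been measured and on what is new or still open speak of the compounds shown alone.

Measured so far in an ADME assay on cells (Macrophage, Mus musculus) for cytotoxicity, read by resazurin assay, with a stated time of 3 days; on this read-out lower numbers stand for stronger inhibition and higher numbers for weaker inhibition:
compound 1, `O=C(Nc1ccc(F)cc1C(F)(F)F)c1cc(Cl)ccc1O`, with 13000 nM
compound 2, `O=C(Nc1ccc(Br)cc1C(F)(F)F)c1cc(Cl)ccc1O`, with 11000 nM
compound 3, `O=C(Nc1cc(C(F)(F)F)ccc1F)c1cc(Cl)ccc1O`, with 2600 nM

Compound 1 and compound 2 share a core and differ in one place, (bromo in place of fluoro on an aromatic carbon). In this assay this gave a 1.2-fold lower number from compound 1 to compound 2 (0.07 log units; within the scatter), so the two values cannot be told apart. Compound 3 is built from the same atoms as compound 1 joined differently; the difference between the two cores is not broken down here. Compound 3 stands lowest of the three, with compound 2 nearest and compound 1 furthest, and both of those gaps lie beyond the scatter.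

Compound 4, `O=C(Nc1cc(C(F)(F)F)ccc1Br)c1cc(Cl)ccc1O`, has not yet been measured. It is related to compound 3 by bromo in place of fluoro on an aromatic carbon. Among the compounds with values here, this is the same kind of change as the one from compound 1 to compound 2, but not the same: in compound 1 the carbon is meta to a trifluoromethyl group and para to a large group, whereas in compound 3 it is ortho to a large group and para to a trifluoromethyl group. The nearest guide remains the measured pair, and the expected step from compound 3 to compound 4 is a 1.1-fold lower number from compound 3 to compound 4 (0.05 log units; within the scatter), placed beside a 1.2-fold lower number from compound 1 to compound 2 (0.07 log units; within the scatter), because that earlier change gave a 1.2-fold lower number from compound 1 to compound 2 (0.07 log units; within the scatter) and stayed within the scatter. On this basis compound 4 is expected to give about 2300 nM in this assay, estimated between 900 nM and 6000 nM.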

Compound 4, half-maximal inhibitory concentration: 2900 nM
The estimate for compound 4 lay 1.3-fold (0.10 log units) below the measured number, and the stated range covers the measured number.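

In this assay, putting bromo in place of fluoro on an aromatic carbon that is ortho to a large group and para to a trifluoromethyl group gave a 1.1-fold higher number from compound 3 to compound 4 (0.05 log units; within the scatter), so the two values cannot be told apart. Set beside the earlier step on the core of compound 1, the same exchange left the number within the scatter on both cores, and the two steps do not differ from each other: the same change on two cores in this assay, a 1.2-fold lower number (0.07 log units; within the scatter) from compound 1 to compound 2 and a 1.1-fold higher number (0.05 log units; within the scatter) from compound 3 to compound 4, 1.3-fold (0.12 log units) apart, within the scatter of two such steps. Within the data shown here, this shows that, across these two pairs, the exchange of fluoro for bromo carried from one core to the other without a readable change in this read-out, but with only two small steps it fixes no direction and does not show that the exchange would stay as quiet on any further core or at any other place on the ring.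

The compounds shown leave open whether a group other than fluoro or bromo at this place, such as a nitrile or an amine, would also stay within the scatter. On these data alone, all four compounds carry the same chloro and hydroxyl groups, so the result of a carboxylic acid or a longer chain in place of either also remains open.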